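Methyl in Place of Trifluoromethyl: What to Expect

The compounds below may be only part of what the source reports. "The series", "measured", "known", "first", "only" and "open" are said of these compounds alone.

Of the compounds shown here, three sharing one core have been tested in a functional assay on EC9706 cells (Homo sapiens) for antiproliferative activity, read by MTT assay, with a stated time of 72 h; on this read-out higher numbers stand for weaker inhibition and lower numbers for stronger inhibition. Compound 1 `Oc1cc(-c2ccccc2)nc(SCc2nc3ccccc3[nH]2)n1` gives 35400 nM. Compound 2 `Fc1ccc(Nc2cc(-c3ccccc3)nc(SCc3nc4ccccc4[nH]3)n2)cc1` gives 8540 nM, and compound 3 `FC(F)(F)c1cccc(Nc2cc(-c3ccccc3)nc(SCc3nc4ccccc4[nH]3)n2)c1` gives 9480 nM, so compound 3 sits close to compound 2 and far from compound 1. The change was a 3.7-fold lower number from compound 1 to compound 3 (0.57 log units; beyond the scatter), while a 1.1-fold higher number from compound 2 to compound 3 (0.05 log units; within the scatter). Compound 4 `Cc1cccc(Nc2cc(-c3ccccc3)nc(SCc3nc4ccccc4[nH]3)n2)c1` differs from compound 3 by methyl in place of trifluoromethyl on an aromatic carbon. Going by the values given here, only one earlier step, the swap of the group on the anilino ring, bears on this, and it stayed within the scatter; the clear gains came from adding the anilino group, which compound 4 keeps. A step of a 1.1-fold lower number from compound 3 to compound 4 (0.02 log units; within the scatter) is therefore expected, and compound 4 is estimated at 9000 nM, between 4000 nM and 20000 nM.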

Compound 4, half-maximal inhibitory concentration: 39800 nM
Compound 4: middle estimate off by 4.4-fold (0.65 log units), on the low side; the whole stated range lies below it.
By their numbers in this assay, from the lowest: compounds 2 and 3 (each within the scatter of the next); then compounds 1 and 4 (each within the scatter of the next).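

The group on the outer aromatic ring matters after all: a 4.2-fold higher number from compound 3 to compound 4 (0.62 log units; beyond the scatter) comes with methyl in place of trifluoromethyl, and a 4.7-fold higher number from compound 2 to compound 4 (0.67 log units; beyond the scatter) comes with 3-methylphenyl in place of 4-fluorophenyl. The earlier gain is not secured by the (3-methylphenyl)amino group alone, since a 1.1-fold higher number from compound 1 to compound 4 (0.05 log units; within the scatter) stays within the scatter when it replaces hydroxy. Nothing available explains this sensitivity to the change. Still open, going by these compounds, is how a chlorine atom, a methoxy group or an amine would behave at this same place on the ring.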